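Aryl urea variation in an antiproliferative series

A few compounds are considered here, and "the series" means these few. Any claim that something is new, unique, unknown or untested is made for them only; others in the source may bear on it.

Measured compounds:
compound 1, `Cc1cccc(NC(=O)Nc2nnc(Sc3ncnc4scc(-c5ccncc5)c34)s2)c1`, 27200 nM
compound 2, `O=C(Nc1ccc(F)cc1)Nc1nnc(Sc2ncnc3scc(-c4ccncc4)c23)s1`, 18900 nM

In a functional assay on T47D cells (Homo sapiens) for antiproliferative activity, read by MTT assay, with a stated time of 48 h (on this read-out lower numbers stand for stronger inhibition and higher numbers for weaker inhibition), compound 1 gives 27200 nM, and compound 2 gives 18900 nM. Among the compounds with values here, the one step between them, a 1.4-fold lower number from compound 1 to compound 2 (0.16 log units; within the scatter), lies within the scatter, so compound 2 carries the lower of the two numbers without being separated from compound 1 beyond the usual spread.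

Compound 3, `O=C(Nc1ccc(Cl)c(C(F)(F)F)c1)Nc1nnc(Sc2ncnc3scc(-c4ccncc4)c23)s1`, differs from compound 2 by 4-chloro-3-(trifluoromethyl)phenyl in place of 4-fluorophenyl on an amide-type nitrogen. Within the data shown here, the only measured step that bears on this place is a 1.4-fold lower number from compound 1 to compound 2 (0.16 log units; within the scatter), a change of the aryl group on the same amide-type nitrogen, and it was within the scatter. Nothing measured covers the entering group itself. The expected step is therefore small, a 1.5-fold lower number from compound 2 to compound 3 (0.16 log units; within the scatter), with wide uncertainty. Compound 3 is estimated at 13000 nM, between 4000 nM and 40000 nM.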

Compound 3, half-maximal inhibitory concentration: 28000 nM
For compound 3 the middle estimate is 2.2-fold (0.33 log units) below the measured one; the range from low to high includes it.
By their numbers in this assay, from the lowest: compounds 2, 1 and 3 (each within the scatter of the next).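

At the aryl group on the amide-type nitrogen, 4-chloro-3-(trifluoromethyl)phenyl in this assay gives a 1.5-fold higher number from compound 2 to compound 3 (0.17 log units; within the scatter) and a 1.0-fold higher number from compound 1 to compound 3 (0.01 log units; within the scatter) in the two comparisons, and both steps stay within the scatter. The group that enters carries 11 heavy atoms, including chlorine and three fluorines, against 7 in 4-fluorophenyl, yet compounds 1, 2 and 3 remain within the scatter of one another, so no aryl change shown at this place separates any two compounds. No supporting measurement is available to explain why these numbers stay together.

Still open, as far as these compounds go, is whether a phenyl group is needed on this nitrogen at all, or whether a cyclohexyl ring, a longer alkyl chain or a phenyl ring bearing a carboxylic acid or an amine would move the number beyond the scatter. Also open, from the compounds shown here alone, is how much the shared core, constant across all three compounds, contributes to the values.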